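This account rests on a few compounds, and the source may have more. Where it says the series, first, only, none or still open, it means among the compounds named here.

Compound 1 `C[C@@H](NC(=O)c1ccc(C#Cc2ccccc2F)cn1)C(C)(C)O` gives 60% in a functional assay on HEK293 cells for positive allosteric modulation of metabotropic glutamate receptor 5 (Rattus norvegicus), read by fluorescence and calcium flux; a higher number here means a larger maximal response, a lower number a smaller maximal response.
Compound 2 `C[C@@H](NC(=O)c1ccc(C#Cc2ccc(F)cc2)cn1)C(C)(C)O` gives 66.2% in this assay.
Compound 3 `C[C@@H](NC(=O)c1ccc(C#Cc2ccncc2)cn1)C(C)(C)O` gives 66.6% in this assay.

Compound 3 holds the highest of the three numbers, yet both neighbours sit within the scatter: a number 0.4 percentage points higher from compound 2 to compound 3 (within the scatter) and a number 6.6 percentage points higher from compound 1 to compound 3 (within the scatter). Compound 4 `C[C@@H](NC(=O)c1ccc(C#CC2CCCC2)cn1)C(C)(C)O` differs from compound 3 in one place: cyclopentyl in place of pyridin-4-yl on a triple-bonded carbon. Every measured step changes the group on that same triple-bonded carbon, and the remaining one was equally small: a number 6.2 percentage points higher from compound 1 to compound 2 (within the scatter). Those steps swap one six-membered aromatic ring for another; none brings in a non-aromatic ring, so they guide only loosely. No step beyond the scatter is expected in this assay, as a number 3.6 percentage points lower from compound 3 to compound 4 (within the scatter). Compound 4 is estimated at 63%, with a range from 45% to 80%.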

Compound 4, largest response reached (reported as efficacy), in percent of the reference or control that the assay uses: 63.7%
Estimate against measurement, compound 4: 0.7 percentage points below, within the range that was stated.
By their numbers in this assay, from the lowest: compounds 1, 4, 2 and 3 (each within the scatter of the next).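

Within the data shown here, compound 4 is the only compound here with a non-aromatic ring on the triple-bonded carbon, and in this assay cyclopentyl stays within the scatter of all three aromatic rings (a number 2.9 percentage points lower from compound 3 to compound 4 (within the scatter)) and (a number 2.5 percentage points lower from compound 2 to compound 4 (within the scatter)) and (a number 3.7 percentage points higher from compound 1 to compound 4 (within the scatter)). Among these four compounds, then, an aromatic ring at this position is not needed to keep the maximal response, and neither is a ring nitrogen or a fluorine. No measured evidence is available to explain this result. What the compounds shown leave open is how an open chain such as n-butyl, an amine or a carboxylic acid would behave on that triple-bonded carbon.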